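The source may report more compounds than this note shows. Statements on the series, on what has been measured and on what is new or still open speak of the compounds shown alone.

Measured so far in a physicochemical assay for solubility, read by spectrophotometry, in phosphate buffer, with a stated time of 18 h, at pH 7.4; on this read-out higher numbers stand for higher solubility and lower numbers for lower solubility:
- compound 1 `CCc1ccc(-c2nc3c(c(C)nn3-c3ccccc3)c(-c3ccccc3[N+](=O)[O-])c2C#N)cc1`: 1200 nM
- compound 2 `CCc1ccc(-c2nc3c(c(C)nn3-c3ccccc3)c(-c3ccccc3C#N)c2C#N)cc1`: 2400 nM
- compound 3 `CCc1ccc(-c2nc3c(c(C)nn3-c3ccccc3)c(-c3ccccc3C)c2C#N)cc1`: 6000 nM

These three compounds share a core and differ in a single group on an aromatic carbon. Compound 3, which carries methyl there, gives the highest of the three numbers in this assay. The next question is compound 4 `CCc1ccc(-c2nc3c(c(C)nn3-c3ccccc3)c(-c3ccccc3S(C)(=O)=O)c2C#N)cc1`, which has methylsulfonyl in place of that methyl: methylsulfonyl in place of methyl on an aromatic carbon.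

Among the compounds with values here, no measured compound carries methylsulfonyl, so the evidence is indirect. Two measured steps end in this same methyl: a 5.0-fold higher number from compound 1 to compound 3 (0.70 log units; beyond the scatter), and a 2.5-fold higher number from compound 2 to compound 3 (0.40 log units; beyond the scatter). Both are modest, and both show that compound 3 stands above the compounds with other groups at this place. Nitro and cyano themselves are not separated, since a 2.0-fold higher number from compound 1 to compound 2 (0.30 log units; within the scatter). Read with caution, these three compounds suggest that leaving methyl for another group may lower the number, though two comparisons make a thin basis. The expected step is therefore a modest one towards a lower number, a 2.5-fold lower number from compound 3 to compound 4 (0.40 log units; beyond the scatter). For compound 4 the estimated value is 2400 nM, with an expected range from 800 nM to 7000 nM.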

Compound 4, solubility: 2200 nM
For compound 4 the middle estimate is 1.1-fold (0.04 log units) above the measured one; the measured number falls inside the stated range.
By their numbers in this assay, from the lowest: compounds 1, 4 and 2 (each within the scatter of the next); then compound 3.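

In this assay the change from methyl to methylsulfonyl gives a 2.7-fold lower number from compound 3 to compound 4 (0.44 log units; beyond the scatter), so a third group at this place on the aromatic carbon now falls short of methyl, and the earlier hint from nitro and cyano holds for one more group. The new group does not open a separate level, since the comparison with cyano gives a 1.1-fold lower number from compound 2 to compound 4 (0.04 log units; within the scatter) and the comparison with nitro gives a 1.8-fold higher number from compound 1 to compound 4 (0.26 log units; within the scatter), and both of these lie within the scatter, so compounds 1, 2 and 4 cannot be told apart in this assay. Among these four compounds, then, only compound 3 stands apart from the rest, and nothing measured here offers a reason for that.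

Going by these compounds, what remains open is whether methyl is special at this place or is simply one of many groups that would stand above nitro, cyano and methylsulfonyl. An amine, a methoxy group, a fluorine atom, a longer chain such as ethyl or plain hydrogen at this place would each help to settle that question.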